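A few compounds are considered here, and "the series" means these few. Any claim that something is new, unique, unknown or untested is made for them only; others in the source may bear on it.

Compounds measured so far:

Compound 1 `O=C(Nc1nc2ccc(Cl)cc2s1)c1cn(-c2ccccc2)nc1-c1ccccc1` – 7810 nM in a functional assay on HT-29 cells (Homo sapiens) for cytotoxicity, read by MTT assay, with a stated time of 72 h; on this read-out higher numbers stand for weaker inhibition and lower numbers for stronger inhibition
Compound 2 `O=C(Nc1nc2ccccc2s1)c1cn(-c2ccccc2)nc1-c1ccc(F)cc1` – 9060 nM
Compound 3 `O=C(Nc1nc2ccc(F)cc2s1)c1cn(-c2ccccc2)nc1-c1ccc(F)cc1` – 4160 nM

All three share one core and differ only in the halogens on their two outer rings. Compound 3 gives the lowest of the three numbers in this assay; its gap to compound 2 is beyond the scatter, whereas compound 1 and compound 3 lie within the scatter of each other, so no order between those two can be read. Within the data shown here, the one step between neighbours, a 2.2-fold lower number from compound 2 to compound 3 (0.34 log units; beyond the scatter), concerns a fluoro added to the fused ring system.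

Compound 4 `O=C(Nc1nc2ccc(Cl)cc2s1)c1cn(-c2ccccc2)nc1-c1ccc(F)cc1` follows from compound 3 by a different change: chloro in place of fluoro on an aromatic carbon. Among the measured compounds shown here, no measured pair shows exactly this swap, so the only guide is indirect: compound 1, which also carries chloro at that place, sits within the scatter of compound 3. On that basis no step beyond the scatter is expected, and the estimated change is a 1.2-fold higher number from compound 3 to compound 4 (0.08 log units; within the scatter). Compound 4 is therefore expected at about 5000 nM in this assay, with a likely range from 2500 nM to 10000 nM.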

Compound 4, half-maximal inhibitory concentration: 3320 nM
Compound 4: middle estimate off by 1.5-fold (0.18 log units), on the high side; the measured number falls inside the stated range.
By their numbers in this assay, from the lowest: compounds 4, 3, 1 and 2 (each within the scatter of the next, the first and the last beyond it).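

Swapping 6-fluoro-1,3-benzothiazol-2-yl for 6-chloro-1,3-benzothiazol-2-yl gives no readable change, with a 1.3-fold lower number from compound 3 to compound 4 (0.10 log units; within the scatter), so these two halogens cannot be told apart at this position. Chloro in place of hydrogen on the same carbon does give a step beyond the scatter, with a 2.7-fold lower number from compound 2 to compound 4 (0.44 log units; beyond the scatter), so either halogen here goes with a lower number than hydrogen in these compounds. With chloro in place, fluoro in place of hydrogen on an aromatic carbon gives a 2.4-fold lower number from compound 1 to compound 4 (0.37 log units; beyond the scatter), and this change is about the same size on both cores: the same change on two cores in this assay, a 2.2-fold lower number (0.34 log units; beyond the scatter) from compound 2 to compound 3 and a 2.4-fold lower number (0.37 log units; beyond the scatter) from compound 1 to compound 4, 1.1-fold (0.03 log units) apart, within the scatter of two such steps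

Going by these compounds, whether the numbers keep falling with a larger halogen such as bromo remains open. The compounds shown also cannot say how a non-halogen group at this position, such as methoxy, an amine or a carboxylic acid, would compare.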